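Thiophene-bearing ether: trifluoromethyl variant of compound 3

The source may report more compounds than this note shows. Statements on the series, on what has been measured and on what is new or still open speak of the compounds shown alone.

Compound 1 `Cn1c(C2CC2)nc2ccc(-n3ccc(OCc4ccc(F)cc4)cc3=O)cc21` gives 40 nM in an assay on CHO cells for displacement of a labelled ligand from melanin-concentrating hormone receptor 1 (Homo sapiens), read by scintillation counting, with a stated time of 1 h; on this read-out lower numbers stand for stronger inhibition and higher numbers for weaker inhibition. Compound 2 `Cn1c(C2CC2)nc2ccc(-n3ccc(OCc4ncc(Cl)cn4)cc3=O)cc21` reaches only the assay limit > 1000 nM in this assay, and the limit of > 1000 nM in this assay, at which 1 of the 3 values shown sits, is noted as such. Compound 3 `Cn1c(C2CC2)nc2ccc(-n3ccc(OCc4ccc(Cl)s4)cc3=O)cc21` gives 19 nM in this assay, the lowest of the two numbers shown, with compound 1 nearest a 2.1-fold lower number from compound 1 to compound 3 (0.32 log units; beyond the scatter). The heteroaryl swap an at least 25-fold higher number from compound 1 to compound 2 (1.39 log units; beyond the scatter) and its reverse at least 52-fold lower number from compound 2 to compound 3 (1.72 log units; beyond the scatter) are the large steps of the set.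

Compound 4 `Cn1c(C2CC2)nc2ccc(-n3ccc(OCc4cc(C(F)(F)F)cs4)cc3=O)cc21` differs from compound 3 as follows: 4-(trifluoromethyl)thiophen-2-yl in place of 5-chlorothiophen-2-yl on a saturated chain carbon bound to an oxygen on an aromatic ring. For the measured compounds named here, no measured step changes a substituent on a thiophen-2-yl group; the only step that bears on it is the modest one from compound 1 to compound 3 a 2.1-fold lower number from compound 1 to compound 3 (0.32 log units; beyond the scatter), which shows that the 5-chlorothiophen-2-yl group is tolerated. Compound 4 is therefore expected to stay close to compound 3, with an estimated step of a 1.8-fold higher number from compound 3 to compound 4 (0.27 log units; within the scatter) that need not exceed the scatter. Compound 4 is estimated at 35 nM in this assay, within 10 nM to 130 nM.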

Compound 4, half-maximal inhibitory concentration: 34 nM
Compound 4: the middle estimate sits 1.0-fold (0.01 log units) above what was measured; the range from low to high includes it.
By their numbers in this assay, from the lowest: compounds 3, 4 and 1 (each within the scatter of the next, the first and the last beyond it). At a limit, above all of these: compound 2.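

In this assay, the two thiophene groups cannot be told apart at this place, on a saturated chain carbon bound to an oxygen on an aromatic ring: a 1.8-fold higher number from compound 3 to compound 4 (0.25 log units; within the scatter), and the comparison with the 4-fluorophenyl group gives a 1.2-fold lower number from compound 1 to compound 4 (0.07 log units; within the scatter). A second substituted thiophen-2-yl group therefore also stands far from the 5-chloropyrimidin-2-yl group, with an at least 29-fold lower number from compound 2 to compound 4 (1.46 log units; beyond the scatter), so this large gap no longer rests on a single thiophene. That gap has only a lower bound, as compound 2 stands at a limit of the assay, not at a number: the limit of > 1000 nM in this assay, at which 1 of the 4 values shown sits.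

From the compounds shown here alone, whether the thiophen-2-yl group needs a substituent at all remains open, as does how a nitrile or a methyl group on it would read in this assay. Also open, going by these compounds, is whether an amine or a carboxylic acid on the thiophene would be accepted at this place.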